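From a Chlorinated Phenyl to a Tert-Butyl Phenyl Amide

The compounds below may be only part of what the source reports. "The series", "measured", "known", "first", "only" and "open" are said of these compounds alone.

Compound 1, `COc1cc(N(Cc2nc3ccccc3[nH]2)C(=O)c2ccc(F)cc2)cc(OC)c1OC`, gives 23600 nM.
Compound 2, `COc1cc(N(Cc2nc3ccccc3[nH]2)C(=O)c2ccc(Br)cc2)cc(OC)c1OC`, gives 14600 nM.
Compound 3, `COc1cc(N(Cc2nc3ccccc3[nH]2)C(=O)c2cccc(Cl)c2)cc(OC)c1OC`, gives > 50000 nM, which is a limit of the assay and not a number.

All three share one core and differ only in the aryl group on the carbonyl carbon. In a functional assay on MGC-803 cells (Homo sapiens) for inhibition, read by MTT assay, with a stated time of 48 h (a lower number here means a stronger inhibitor, a higher number a weaker inhibitor), compound 1 and compound 2 sit close together, as the step of a 1.6-fold lower number from compound 1 to compound 2 (0.21 log units; within the scatter) shows. Going by these compounds, compound 3 stands only at a limit, the reading of the limit of > 50000 nM in this assay, at which 1 of the 3 values shown sits, so its true value is unknown beyond that. Both steps toward it rose: an at least 2.1-fold higher number from compound 1 to compound 3 (0.32 log units; beyond the scatter) and an at least 3.4-fold higher number from compound 2 to compound 3 (0.53 log units; beyond the scatter).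

Compound 4, `COc1cc(N(Cc2nc3ccccc3[nH]2)C(=O)c2ccc(C(C)(C)C)cc2)cc(OC)c1OC`, has not yet been measured. It differs from compound 3 by 4-(tert-butyl)phenyl in place of 3-chlorophenyl on a carbonyl carbon, bringing back a phenyl substituted as in the 4-fluorophenyl of compound 1 and the 4-bromophenyl of compound 2. Because the steps of an at least 2.1-fold higher number from compound 1 to compound 3 (0.32 log units; beyond the scatter) and an at least 3.4-fold higher number from compound 2 to compound 3 (0.53 log units; beyond the scatter) both raised the number, a return in the other direction is expected for compound 4, an estimated step of an at least 2.5-fold lower number from compound 3 to compound 4 (0.39 log units; beyond the scatter). Among the measured compounds shown here, no measured step covers the tert-butyl group itself, so the range is wide. Compound 4 is expected to give about 20000 nM in this assay, between 6000 nM and 60000 nM.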

Compound 4, half-maximal inhibitory concentration: > 50000 nM
Compound 4: no number, only a limit (the forecaster's own chance of this, stated with the estimate: 25%); at least 2.5-fold (0.39 log units) between middle value and limit.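

In this assay, among the compounds shown here, putting tert-butyl on the aromatic carbon that carries bromo or fluoro in the earlier compounds weakens the compound, with steps of an at least 3.4-fold higher number from compound 2 to compound 4 (0.53 log units; beyond the scatter) and an at least 2.1-fold higher number from compound 1 to compound 4 (0.32 log units; beyond the scatter). Compounds 1 and 2 alone might have suggested that a 4-substituted phenyl on the carbonyl carbon is enough to keep a readable value, but compound 4 goes against that, so the identity of the substituent matters as well. Compound 4, like compound 3, gives only a limit of the assay and not a number, so the step between them cannot be read: the limit of > 50000 nM in this assay, at which 2 of the 4 values shown sit.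

Going by these compounds, how far beyond that limit either compound lies remains unknown. Also open, on these data alone, is how a methyl group, an amine or a carboxylic acid would behave on that same aromatic carbon.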